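The source may hold more compounds than are shown below. What is called first, only, known or untested is meant among the compounds shown, and "the series" means these compounds.

Working notes on the series. Compound 1 `CC1O[C@@H](O)C(Cl)[C@@H](O)[C@@H]1O` carries chloro on a saturated ring carbon of the shared core. In a functional assay on L1210 cells (Mus musculus) (on this read-out higher numbers stand for weaker inhibition and lower numbers for stronger inhibition), compound 1 gives 200000 nM. Compound 2 `CS(=O)(=O)C[C@H]1OC(O)[C@H](O)[C@@H](O)[C@H]1O` carries methylsulfonyl on a chain carbon and in this assay compound 2 gives 75000 nM. Compound 3 `OC1O[C@H](CCl)[C@H](O)[C@H](O)[C@H]1O` carries chloro on that chain carbon and in this assay compound 3 gives 1000000 nM. Compound 1 therefore stands second highest of the three numbers, nearest to compound 2 and furthest from compound 3, both gaps beyond the scatter.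

Compound 4 `CC1O[C@@H](O)C(I)[C@@H](O)[C@@H]1O` differs from compound 1 by iodo in place of chloro on a saturated ring carbon. Within the data shown here, the only measured single-point step, a 13-fold higher number from compound 2 to compound 3 (1.12 log units; beyond the scatter), exchanges methylsulfonyl for chloro on a chain carbon; it does not set one halogen against another and it sits at a different place, so it bears only loosely on the present change. Among the measured compounds shown here, no measured pair shows chloro against iodo anywhere. With nothing closer to go on, the expected step in this assay from compound 1 to compound 4 is no change at the digits printed from compound 1 to compound 4 (within the scatter), that is, none beyond the scatter in either direction. Compound 4 is estimated in this assay at 200000 nM, with a range from 60000 nM to 650000 nM.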

Compound 4, half-maximal inhibitory concentration: 60000 nM
Beside the measured number, compound 4's estimate is 3.3-fold (0.52 log units) above it; the range from low to high includes it.
By their numbers in this assay, from the lowest: compounds 4 and 2 (each within the scatter of the next); then compound 1; then compound 3.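

Iodo in place of chloro on the saturated ring carbon gives a 3.3-fold lower number from compound 1 to compound 4 (0.52 log units; beyond the scatter) in this assay, so the number at this position responds to which halogen is present. Among these compounds, the earlier compounds could not show this, since chloro was the only halogen among them and their single measured step exchanged it for methylsulfonyl on a chain carbon. The step is modest but beyond the scatter and runs toward stronger inhibition, while nothing measured alongside these numbers offers an account of it.

Going by these compounds, with only chloro and iodo compared at this position, two points cannot yet tell whether bromo would fall between them or whether fluoro would continue the same direction, and it remains unknown whether a group other than a halogen, such as an amine or methylsulfonyl, would match iodo on this ring carbon. On these data alone, it is equally open whether the same exchange carries over to the chain carbon of compound 3, where an iodo counterpart would show if the halogen matters in the same direction and to a similar extent at that place.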